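Swapping an ethyl for chloro on a fused thiophene core

The compounds below may be only part of what the source reports. "The series", "measured", "known", "first", "only" and "open" are said of these compounds alone.

Among the measured compounds shown here, in an ADME assay on HeLa cells (Homo sapiens) for cytotoxicity, read by MTT assay, with a stated time of 2 days (on this read-out lower numbers stand for higher toxicity in this test and higher numbers for lower toxicity in this test), compound 2 `CCOC(=O)c1sc2cc(Oc3ccnc(C(=O)NC)c3)ccc2c1CC` gives 16700 nM, the only number recorded in this set. Compound 1 `CCOC(=O)c1cc2ccc(Oc3ccnc(C(=O)NC)c3)cc2s1` gives only a limit, > 100000 nM. For the measured compounds named here, the single measured step, an at least 5.9-fold lower number from compound 1 to compound 2 (0.77 log units; beyond the scatter), touches the ring position now in question, where compound 3 `CCOC(=O)c1sc2cc(Oc3ccnc(C(=O)NC)c3)ccc2c1Cl` carries chloro in place of ethyl on an aromatic carbon. That step shows the ethyl group pulling the number down beyond the scatter; removing it for a smaller group points the other way, though how far is uncertain. Compound 3 is therefore expected to give about 35000 nM, within 12000 nM to 100000 nM. The expected step is a 2.1-fold higher number from compound 2 to compound 3 (0.32 log units; beyond the scatter).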

Compound 3, half-maximal cytotoxic concentration: 45600 nM
Estimate against measurement, compound 3: 1.3-fold (0.11 log units) below, and the stated range covers the measured number.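

In this assay, the position responds to which group it carries, not only to whether hydrogen is replaced: chloro in place of ethyl gives a 2.7-fold higher number from compound 2 to compound 3 (0.44 log units; beyond the scatter). Chloro in place of hydrogen also lowers the number, with an at least 2.1-fold lower number from compound 1 to compound 3 (0.34 log units; beyond the scatter), so both substituents read on the same side of the unsubstituted core. Compound 1 is only a limit, so this last step has a bound and no exact size: the limit of > 100000 nM in this assay, at which 1 of the 3 values shown sits.

From the compounds shown here alone, how an amine or a methoxy group at this position would read remains open. So does whether a longer chain would take the number lower still.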